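This account rests on a few compounds, and the source may have more. Where it says the series, first, only, none or still open, it means among the compounds named here.

Measured compounds:
- Compound 1, `Brc1cn2ccnc2c(-c2ccc3ncn(C4CCCCC4)c3c2)n1`, gives 37.6%.
- Compound 2, `c1ccc2c(-c3cn4ccnc4c(-c4ccc5ncn(C6CCCCC6)c5c4)n3)cccc2c1`, gives 23%.
- Compound 3, `Fc1ccc(-c2cn3ccnc3c(-c3ccc4ncn(C5CCCCC5)c4c3)n2)cc1`, gives 37.8%.

In a functional assay on UO-31 cells (Homo sapiens) for inhibition, read by sulforhodamine B assay, with a stated time of 48 h, tested at 10 uM (a higher number here means more inhibition at the concentration tested (going by the name of the read-out), a lower number less inhibition), compound 2 stands lowest of the three numbers. Its nearest neighbour is compound 1, reached by the step of a number 14.6 percentage points lower from compound 1 to compound 2 (beyond the scatter), and its furthest is compound 3, reached by the step of a number 14.8 percentage points higher from compound 2 to compound 3 (beyond the scatter); both of these steps lie beyond the scatter, so the number of compound 2 is the lowest of the three here.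

Compound 4, `Clc1ccc(-c2cn3ccnc3c(-c3ccc4ncn(C5CCCCC5)c4c3)n2)cc1`, is the next compound in line. The change from compound 2 is 4-chlorophenyl in place of naphthalen-1-yl on an aromatic carbon. The step that bears on it most directly is the one that also removed naphthalen-1-yl, a number 14.8 percentage points higher from compound 2 to compound 3 (beyond the scatter), which was modest and upward. The step of a number 0.2 percentage points higher from compound 1 to compound 3 (within the scatter) stayed within the scatter, so a 4-fluorophenyl and a bromo gave alike numbers, and a 4-chlorophenyl is expected to behave much like the 4-fluorophenyl. A modest upward step is therefore expected, a number 14 percentage points higher from compound 2 to compound 4 (beyond the scatter). For compound 4 the estimate is 37%, with a range from 25% to 49%.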

Compound 4, a percentage reported as inhibition, at one concentration (the size of the read-out at that concentration, not a potency): 36.1%
For compound 4 the middle estimate is 0.9 percentage points above the measured one; low and high end bracket the measured number.
By their numbers in this assay, from the lowest: compound 2; then compounds 4, 1 and 3 (each within the scatter of the next).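

In this assay, changing the halogen on the phenyl ring from fluoro to chloro makes no readable difference (a number 1.7 percentage points lower from compound 3 to compound 4 (within the scatter)). The 4-chlorophenyl group also reads level with a bare bromo at this position (a number 1.5 percentage points lower from compound 1 to compound 4 (within the scatter)), yet it stands apart from naphthalen-1-yl (a number 13.1 percentage points higher from compound 2 to compound 4 (beyond the scatter)), so a second compound with a single phenyl ring now separates from compound 2 by about the same margin as compound 3 did. Nothing measured here explains why compound 2 stands apart.

The groups shown at this position are only bromo and all-carbon aromatic rings, so what an amine, a carboxylic acid or a pyridine ring would do there stays open. These readings come from one concentration and do not give potency.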